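Dihydropyridine ester series: ether side chain swap on a second core

The compounds below may be only part of what the source reports. "The series", "measured", "known", "first", "only" and "open" are said of these compounds alone.

The set rests on one shared core carrying a saccharin-type ester chain; the compounds differ in the ether on the enol side chain and in the nitrophenyl on the saturated ring carbon. Compound 1 is `COCCO/C(O)=C1\C(C)=NC(C)=C(C(=O)OCCCN2C(=O)c3ccccc3S2(=O)=O)C1c1cccc([N+](=O)[O-])c1`, compound 2 is `CC1=NC(C)=C(C(=O)OCCCN2C(=O)c3ccccc3S2(=O)=O)C(c2cccc([N+](=O)[O-])c2)/C1=C(\O)OCC1CCCO1`, compound 3 is `COCCO/C(O)=C1\C(C)=NC(C)=C(C(=O)OCCCN2C(=O)c3ccccc3S2(=O)=O)C1c1ccccc1[N+](=O)[O-]`, and compound 4, not yet measured, is `CC1=NC(C)=C(C(=O)OCCCN2C(=O)c3ccccc3S2(=O)=O)C(c2ccccc2[N+](=O)[O-])/C1=C(\O)OCC1CCCO1`.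

In a functional assay (aorta) with Oryctolagus cuniculus as the target (a lower number here means a stronger inhibitor, a higher number a weaker inhibitor), compound 1 gives 6.8 nM. Compound 2 gives 10.5 nM in this assay, and compound 3 gives 2.7 nM in this assay.

Two changes are measured. The first, (oxolan-2-yl in place of methoxymethyl on a saturated chain carbon bound to an oxygen on an unsaturated carbon), produced a 1.5-fold higher number from compound 1 to compound 2 (0.19 log units; within the scatter). The second, (2-nitrophenyl in place of 3-nitrophenyl on a saturated ring carbon), produced a 2.5-fold lower number from compound 1 to compound 3 (0.40 log units; beyond the scatter); this is also how the core of compound 3 differs from the core of compound 1.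

Among the compounds with values here, compound 4 carries the first change on the core of compound 3: oxolan-2-yl in place of methoxymethyl on a saturated chain carbon bound to an oxygen on an unsaturated carbon. The place of the change is the same word for word as for compound 1 to compound 2, so it is the same change made on a different core. Within the data shown here, with only one measured instance, the expectation is that the step from compound 3 to compound 4 in this assay is small, about the size of a 1.5-fold higher number from compound 1 to compound 2 (0.19 log units; within the scatter), which lay within the scatter; the expected step is a 1.5-fold higher number from compound 3 to compound 4 (0.17 log units; within the scatter). Compound 4 is therefore expected to give about 4 nM in this assay, most likely between 2 nM and 9 nM.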

Compound 4, half-maximal inhibitory concentration: 6.8 nM
Estimate against measurement, compound 4: 1.7-fold (0.23 log units) below, within the range that was stated.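

On the second core, replacing methoxymethyl with oxolan-2-yl gives a 2.5-fold higher number from compound 3 to compound 4 (0.40 log units; beyond the scatter), and this agrees with the earlier reading of the same change: the same change on two cores in this assay, a 1.5-fold higher number (0.19 log units; within the scatter) from compound 1 to compound 2 and a 2.5-fold higher number (0.40 log units; beyond the scatter) from compound 3 to compound 4, 1.6-fold (0.21 log units) apart, within the scatter of two such steps. Read on the oxolan-2-yl side, the change to 2-nitrophenyl gives a 1.5-fold lower number from compound 2 to compound 4 (0.19 log units; within the scatter), and this also agrees with its earlier reading: the same change on two cores in this assay, a 2.5-fold lower number (0.40 log units; beyond the scatter) from compound 1 to compound 3 and a 1.5-fold lower number (0.19 log units; within the scatter) from compound 2 to compound 4, 1.6-fold (0.21 log units) apart, within the scatter of two such steps. Within the data shown here, both changes therefore carry from one core to the other in the same direction and with no size difference beyond the scatter, but each rests on only two readings, one within the scatter and one beyond it, so this does not show that the steps are equal, that they would hold on a further core, or why they arise.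

The compounds shown leave open how an amine or a longer chain would behave in place of methoxymethyl or oxolan-2-yl, and how a nitrile would compare with the nitro group on the phenyl ring. The saccharin-type ester chain is the same throughout and all readings come from this assay, so neither the part played by that chain nor the behaviour of these changes in any other test can be read here.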